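This account rests on a few compounds, and the source may have more. Where it says the series, first, only, none or still open, it means among the compounds named here.

Measured so far:
compound 1, `Brc1ccc(-c2cc3ccccc3o2)cc1`, > 100000 nM
compound 2, `Cc1cccc2cc(-c3ccccc3Br)oc12`, 100000 nM
compound 3, `Cc1ccc2oc(-c3ccc(Br)cc3)cc2c1`, > 100000 nM

All three were tested in an assay on cells for inhibition of Amine oxidase [flavin-containing] A (Homo sapiens), read by fluorescence and Amplex Red, with a stated time of 15 min; a lower number here means a stronger inhibitor, a higher number a weaker inhibitor. For compound 1 the value > 100000 nM is a limit of the assay, not a number. For compound 3 the value > 100000 nM is likewise a limit. Going by the values given here, compound 2 is the only one with a number, 100000 nM. From compound 3 to compound 1 the change is hydrogen in place of methyl on an aromatic carbon, and the step that the two limits leave unreadable from compound 3 to compound 1 cannot be read. The cores of compound 2 and compound 3 differ, but that difference is not broken down here. Compound 4, `Brc1ccccc1-c1cc2ccccc2o1`, is not yet measured; from compound 2 it differs by hydrogen in place of methyl on an aromatic carbon, the same kind of change as from compound 3 to compound 1, though the place is not the same: ortho and meta to a fused ring here, meta and para to a fused ring there. Because (the limit of > 100000 nM in this assay, at which 2 of the 3 values shown sit), little movement is expected. Compound 4 is expected to sit at about 100000 nM, quite possibly reported only as a limit. That means an estimated step of no change at the digits printed from compound 2 to compound 4 (within the scatter).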

Compound 4, half-maximal inhibitory concentration: 8120 nM
The estimate for compound 4 lay 12-fold (1.09 log units) above the measured number; the measured number lies below the stated range.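

In this assay, hydrogen in place of methyl on an aromatic carbon gives a 12-fold lower number from compound 2 to compound 4 (1.09 log units; beyond the scatter), so on this core the change yields a clearly stronger inhibitor. The same change from compound 3 to compound 1 cannot be read, because both compounds sit at a limit of the assay rather than at a number: the limit of > 100000 nM in this assay, at which 2 of the 4 values shown sit. The gain is therefore shown on one core only, and these data cannot say whether it carries over to another core, where the methyl also stands in a different place.

The compounds shown leave open how other groups at that carbon would behave. An ethyl, a methoxy or an amine there is not among them.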